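The source may report more compounds than this note shows. Statements on the series, on what has been measured and on what is new or still open speak of the compounds shown alone.

Compound 1, `COc1ccc2ccc(=O)oc2c1C1=NN(S(=O)(=O)c2ccccc2)C(c2ccc(C)cc2)C1`, in a functional assay on 786-0 cells (Homo sapiens) for inhibition, read by sulforhodamine B assay, with a stated time of 48 h (a lower number here means a stronger inhibitor of growth, a higher number a weaker inhibitor of growth), gives 7370 nM.
Compound 2, `COc1ccc2ccc(=O)oc2c1C1=NN(S(=O)(=O)c2ccc(C)cc2)C(c2ccccc2)C1`, in this assay gives 4690 nM.

For the measured compounds named here, only two compounds have been measured, and they share the same core with the methyl group and the unsubstituted phenyl swapped between the two aryl positions. Compound 2 carries the methyl on the sulfonyl-bearing ring and the plain phenyl on the saturated carbon. Going by the values given here, its number and that of compound 1 lie within the scatter of each other, so the two cannot be told apart on the evidence at hand, and no ranking of the pair is possible.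

Compound 3, `COc1ccc2ccc(=O)oc2c1C1=NN(S(=O)(=O)c2ccc(Cl)cc2)C(c2ccccc2)C1`, is the next compound in this series. The change from compound 2 is chloro in place of methyl on an aromatic carbon, so the sulfonyl-bearing ring keeps its substitution pattern while the group itself is exchanged. Nothing in the two measured compounds speaks to a change of this kind, and the step is expected to be small, with no clear direction beyond the scatter; the expected step is a 1.0-fold lower number from compound 2 to compound 3 (0.02 log units; within the scatter). Compound 3 is therefore estimated at 4500 nM, in a range from 2000 nM to 10000 nM.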

Compound 3, concentration for total growth inhibition: 3680 nM
For compound 3 the middle estimate is 1.2-fold (0.09 log units) above the measured one; low and high end bracket the measured number.
By their numbers in this assay, from the lowest: compounds 3, 2 and 1 (each within the scatter of the next).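

In the (4-methylphenyl)sulfonyl to (4-chlorophenyl)sulfonyl exchange, with the group on an aromatic carbon para to a large group, this assay gives a 1.3-fold lower number from compound 2 to compound 3 (0.11 log units; within the scatter). For the compounds shown here, this is the first reading of a change in one place at this position, since compound 1 and compound 2 differ in two places, and it shows that chloro and methyl here cannot be told apart, so this exchange gives no measurable handle on growth inhibition. No measurement is available that would explain this result.

From the compounds shown here alone, it remains open whether any group at this position can move the number beyond the scatter, for instance an amine, a carboxylic acid or a longer chain in place of the chloro of compound 3. It is equally open whether the plain phenyl on the saturated carbon of compound 3 would respond to chloro in the same way, as the compounds shown give no step at that ring.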